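The source may hold more compounds than are shown below. What is called first, only, known or untested is meant among the compounds shown, and "the series" means these compounds.

Measured compounds and their values:
compound 1 `C=CCn1c(=O)/c(=C\c2cccc(C)c2)[nH]c(=O)/c1=C\c1ccccc1OC` gives 16700 nM;
compound 2 `C=CCn1c(=O)/c(=C\c2ccc(Cl)c(Cl)c2)[nH]c(=O)/c1=C\c1ccccc1` is reported as "not active" (no number reported), with no number given;
compound 3 `C=CCn1c(=O)/c(=C\c2cc(F)ccc2C)[nH]c(=O)/c1=C\c1ccccc1OC` gives 2600 nM.

All three share one core, and they differ in the groups hung on the two double-bonded chain carbons. In a functional assay on HL-60 cells (Homo sapiens) for cytotoxicity, read by CCK-8 assay, with a stated time of 72 h (a higher number here means a weaker inhibitor, a lower number a stronger inhibitor), compound 1 stands at the highest of the two numbers reported, so it is the weaker of the two numbered compounds. Its nearest neighbour is compound 3: the step of a 6.4-fold lower number from compound 1 to compound 3 (0.81 log units; beyond the scatter) shows that exchanging 5-fluoro-2-methylphenyl for 3-methylphenyl at that position gave a clearly stronger compound. Going by the values given here, compound 2 is reported without a number and differs from compound 1 in two places at once, so its value shows only that such changes can also abolish activity.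

Compound 4 `C=CCn1c(=O)/c(=C\c2ccccc2OC)[nH]c(=O)/c1=C\c1ccccc1OC` is not yet measured. It differs from compound 1 in one place: 2-methoxyphenyl in place of 3-methylphenyl on a double-bonded chain carbon bound to an aromatic carbon. Among the compounds with values here, the single measured step that bears on this position is the one from compound 1 to compound 3, which was modest in size. Within the data shown here, no measured pair tells how 2-methoxyphenyl itself behaves at this position, so the expected step of a 1.7-fold lower number from compound 1 to compound 4 (0.22 log units; within the scatter) is small and uncertain. Compound 4 is therefore expected to give about 10000 nM in this assay, with a range from 3000 nM to 35000 nM.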

Compound 4, half-maximal inhibitory concentration: 15700 nM
Compound 4: the middle estimate sits 1.6-fold (0.20 log units) below what was measured; the range from low to high includes it.
By their numbers in this assay, from the lowest: compound 3; then compounds 4 and 1 (each within the scatter of the next).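

In this assay, the step of a 1.1-fold lower number from compound 1 to compound 4 (0.03 log units; within the scatter) means that 2-methoxyphenyl and 3-methylphenyl cannot be told apart at this place on a double-bonded chain carbon bound to an aromatic carbon, even though 2-methoxyphenyl brings an oxygen and a hydrogen-bond acceptor that 3-methylphenyl lacks. The step of a 6.0-fold higher number from compound 3 to compound 4 (0.78 log units; beyond the scatter) sets compound 3 clearly apart from compound 4, just as it stands apart from compound 1, so the gain seen earlier is not shared by every replacement of 3-methylphenyl and, among these three compounds, belongs to 5-fluoro-2-methylphenyl alone. Nothing measured here explains why that group differs from the other two.

The compounds shown do not separate the fluorine from the methyl in 5-fluoro-2-methylphenyl, so it remains open whether either one alone would give the same result at this place. Also open, from the compounds shown here alone, is how a phenyl group carrying an amine or a carboxylic acid would behave here, since every group compared so far carries only small neutral substituents.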